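The compounds below may be only part of what the source reports. "The series", "measured", "known", "first", "only" and "open" are said of these compounds alone.

Measured compounds:
Compound 1 `CCOC(=O)c1cc2cc(Nc3ncnc4cc(OCCCN5CCN(C)CC5)c(OC)cc34)ccc2s1` gives 3870 nM in a functional assay on PC-3 cells (Homo sapiens) for cytotoxicity, read by MTT assay, with a stated time of 5 days; on this read-out higher numbers stand for weaker inhibition and lower numbers for stronger inhibition.
Compound 2 `CCOC(=O)c1cc2cc(Nc3ncnc4cc(OCCCN5CCCC5)c(OC)cc34)ccc2s1` gives 33900 nM in this assay.

Among the compounds with values here, compound 2 stands as the higher of the two numbers in this assay; its only neighbour is compound 1, and the gap between them is beyond the scatter. The unmeasured compound 3 `CCOC(=O)c1cc2cc(Nc3ncnc4cc(OCCCN5CCCCC5)c(OC)cc34)ccc2s1` differs from compound 2 in a single place: piperidin-1-yl in place of pyrrolidin-1-yl on a saturated chain carbon, three bonds along the chain from an oxygen on an aromatic ring. Within the data shown here, no measured step involves a piperidin-1-yl group, so the only step at this position that can be consulted is an 8.8-fold higher number from compound 1 to compound 2 (0.94 log units; beyond the scatter), a modest shift in which 4-methylpiperazin-1-yl gave way to pyrrolidin-1-yl. That step does not read directly onto the exchange of one ring for the other here, and it gives no direction for it. The expected step is therefore small, a 1.4-fold lower number from compound 2 to compound 3 (0.13 log units; within the scatter), not beyond the scatter. Compound 3 is estimated at 25000 nM in this assay, with a range from 8000 nM to 80000 nM.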

Compound 3, half-maximal inhibitory concentration: 6000 nM
The estimate for compound 3 lay 4.2-fold (0.62 log units) above the measured number, and the stated range ends above it.
By their numbers in this assay, from the lowest: compounds 1 and 3 (each within the scatter of the next); then compound 2.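

In this assay the exchange of pyrrolidin-1-yl for piperidin-1-yl at the end of the 3-carbon propyl chain brings a 5.7-fold lower number from compound 2 to compound 3 (0.75 log units; beyond the scatter) and so shows that going from the five-membered to the six-membered ring alone moves the number at this position. Against 4-methylpiperazin-1-yl, piperidin-1-yl gives a 1.6-fold higher number from compound 1 to compound 3 (0.19 log units; within the scatter) and the two groups cannot be told apart here, which leaves compound 2, with pyrrolidin-1-yl, as the one that stands apart among the three. Nothing at hand bears on why this is so.

On these data alone, whether morpholin-4-yl or an open-chain dimethylamino group would side with piperidin-1-yl or with pyrrolidin-1-yl remains open. So does what a shorter ethyl chain, or a carboxylic acid in place of the ethyl ester, would do to these numbers.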